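Notes on the aryl change from compound 3 to compound 4

The source may report more compounds than this note shows. Statements on the series, on what has been measured and on what is new or still open speak of the compounds shown alone.

Compound 1 `N#CC1=C(N)Oc2c(c3nc4ccccc4nc3c3ccccc23)C12C(=O)N(Cc1cnnn1-c1cccc(Cl)c1)c1ccccc12` — a functional assay on MCF7 cells (Homo sapiens) for antiproliferative activity, read by MTT assay, with a stated time of 48 h; on this read-out lower numbers stand for stronger inhibition and higher numbers for weaker inhibition: 43600 nM
Compound 2 `N#CC1=C(N)Oc2c(c3nc4ccccc4nc3c3ccccc23)C12C(=O)N(Cc1cnnn1-c1ccc(N)cc1)c1ccccc12` — this assay: > 50000 nM, a reporting limit rather than a number
Compound 3 `Cc1cccc(-n2nncc2CN2C(=O)C3(C(C#N)=C(N)Oc4c(N)cc5nc6ccccc6nc5c43)c3ccccc32)c1` — this assay: > 50000 nM, likewise a limit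

Compound 3 therefore has no number of its own; it is one of the two entries that sit at the limit (the limit of > 50000 nM in this assay, at which 2 of the 3 values shown sit), and only compound 1 gives a measured value. The change to compound 4 `N#CC1=C(N)Oc2c(N)cc3nc4ccccc4nc3c2C12C(=O)N(Cc1cnnn1-c1ccc(F)cc1)c1ccccc12` is 4-fluorophenyl in place of 3-methylphenyl on an aromatic nitrogen. For the measured compounds named here, one measured step concerns the same aromatic nitrogen: an at least 1.1-fold higher number from compound 1 to compound 2 (0.05 log units; that floor lies within the scatter), an exchange of 3-chlorophenyl for 4-aminophenyl whose floor lies within the scatter and which also ends at the limit. Going by the values given here, no measured pair separates a fluorine from a methyl at this place, and a 3-substituted against a 4-substituted phenyl is covered by that single step alone. For compound 4 the expected step is a number no higher from compound 3 to compound 4 (the limit leaves the size open), which cannot be told apart from no change. Compound 4 is accordingly estimated at 50000 nM, within 25000 nM to 100000 nM, with a fair chance that again only a limit is reported.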

Compound 4, half-maximal inhibitory concentration: > 50000 nM
Compound 4 ended at the assay's limit; the forecaster's own chance of this, stated with the estimate: 60%; the middle value sits exactly at the limit.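

No step can be read from compound 3 to compound 4, as both entries are limits and not numbers: the limit of > 50000 nM in this assay, at which 3 of the 4 values shown sit.

The compounds shown leave open whether 4-fluorophenyl and 3-methylphenyl on the aromatic nitrogen differ at all in this assay.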